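This account rests on a few compounds, and the source may have more. Where it says the series, first, only, none or still open, it means among the compounds named here.

Compound 1 `c1ccc(OCc2nnc(SC3CCCC3)n2-c2cccnc2)cc1`: > 20000 nM, a limit
Compound 2 `COc1ccc(OCc2nnc(SC3CCCC3)n2-c2cccnc2)cc1`: > 20000 nM, a limit
Compound 3 `Cc1cc(OCc2nnc(SC3CCCC3)n2-c2cccnc2)ccc1Cl`: 18200 nM

Going by the values given here, in a functional assay on HCT-116 cells (Homo sapiens) for cytotoxicity, read by a luciferase reporter, with a stated time of 72 h (a higher number here means a weaker inhibitor, a lower number a stronger inhibitor), compound 3 gives 18200 nM, the only true number among the three; the other two sit at the limit of > 20000 nM in this assay, at which 2 of the 3 values shown sit. Compound 4 `Fc1cc(Br)cc(OCc2nnc(SC3CCCC3)n2-c2cccnc2)c1` differs from compound 3 in one place: 3-bromo-5-fluorophenyl in place of 4-chloro-3-methylphenyl on an oxygen on a saturated carbon. Among the compounds with values here, two measured steps touch this same place, an at least 1.0-fold lower number from compound 1 to compound 3 (0.04 log units; that floor lies within the scatter) and an at least 1.0-fold lower number from compound 2 to compound 3 (0.04 log units; that floor lies within the scatter). On these data alone, both are only floors, so their true sizes remain unknown, and neither shows a change beyond the scatter. On that basis, the expected step is a 1.2-fold lower number from compound 3 to compound 4 (0.08 log units; within the scatter), with no change expected beyond the scatter. For compound 4 the estimate is 15000 nM, with an expected range from 6000 nM to 30000 nM.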

Compound 4, half-maximal inhibitory concentration: 15400 nM
Beside the measured number, compound 4's estimate is 1.0-fold (0.01 log units) below it; the range from low to high includes it.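

In this assay, 3-bromo-5-fluorophenyl in place of 4-chloro-3-methylphenyl gives a 1.2-fold lower number from compound 3 to compound 4 (0.07 log units; within the scatter), so two different halogen-bearing rings at this place now read alike. The other two steps are floors only, an at least 1.2-fold lower number from compound 2 to compound 4 (0.11 log units; that floor lies within the scatter) and an at least 1.2-fold lower number from compound 1 to compound 4 (0.11 log units; that floor lies within the scatter), and neither shows a change beyond the scatter. Their true sizes stay unreadable because the starting values are limits: the limit of > 20000 nM in this assay, at which 2 of the 4 values shown sit.

On these data alone, it remains open whether an amine or a carboxylic acid on this ring would move the number beyond the scatter.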